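The compounds below may be only part of what the source reports. "The series", "measured", "known", "first", "only" and "open" are said of these compounds alone.

Three compounds from the same series give a first picture of the read-out. Compound 1 `CC(=O)N1C[C@@H](C(=O)N2CCN(c3ccc(C)cc3[C@@H](NC(=O)CCN(C)C)C(C)C)CC2)[C@H](c2ccc(Cl)cc2)C1` shows 7.6 nM in an assay on HEK293 cells for displacement of a labelled ligand from Melanocortin receptor 4 (Homo sapiens); on this read-out higher numbers stand for weaker inhibition and lower numbers for stronger inhibition. Compound 2 `CNCC(=O)N[C@H](c1cc(C)ccc1N1CCN(C(=O)[C@@H]2CN(C3CCOCC3)C[C@H]2c2ccc(Cl)cc2)CC1)C(C)C` shows 2.1 nM in this assay. Compound 3 `CC(C)[C@H](NC(=O)CCN(C)C)c1cccc(F)c1N1CCN(C(=O)[C@@H]2CN(C(C)C)C[C@H]2c2cc(F)ccc2F)CC1` shows 2050 nM in this assay, the highest of the three numbers and well beyond the scatter of both others. No pair among these three differs in one place only, so no single step has been counted between them; the three numbers are simply what they show.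

Compound 4 `CC(C)[C@H](NC(=O)CCN(C)C)c1cccc(F)c1N1CCN(C(=O)[C@@H]2CN(C(C)C)C[C@H]2c2ccc(C(F)(F)F)cc2F)CC1` has not yet been measured. It differs from compound 3 in one place: 2-fluoro-4-(trifluoromethyl)phenyl in place of 2,5-difluorophenyl on a saturated ring carbon. Compound 1 and compound 2 both carry a 4-chlorophenyl on that saturated ring carbon and sit far lower, while compound 3 with its 2,5-difluorophenyl sits highest, so a downward step in this assay is expected from this change, of moderate size rather than beyond what compound 3 shows. For compound 4 the expected value in this assay is 400 nM, with a range from 80 nM to 2500 nM, which corresponds to an expected step of a 5.1-fold lower number from compound 3 to compound 4 (0.71 log units; beyond the scatter).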

Compound 4, inhibition constant: 61 nM
For compound 4 the middle estimate is 6.6-fold (0.82 log units) above the measured one; measured number outside the range, below it.
By their numbers in this assay, from the lowest: compound 2; then compound 1; then compound 4; then compound 3.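

Replacing 2,5-difluorophenyl with 2-fluoro-4-(trifluoromethyl)phenyl on the saturated ring carbon gives a 34-fold lower number from compound 3 to compound 4 (1.53 log units; beyond the scatter) in this assay. The earlier compounds shown here differed in several places at once, so they could not separate this aryl group from the rest of the structure; this step shows that the change at this one place is enough to move the number by a large amount. Nothing available explains the size of the step.

The compounds shown leave open whether the step belongs to the entering trifluoromethyl or to the leaving fluorine of the 2,5-difluorophenyl. They also leave open how a 4-chlorophenyl, a 4-cyanophenyl or a 4-methoxyphenyl would read at this place on the core of compound 3.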